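Swapping a cyanomethyl ether for a 4-bromobenzyl ether

The source may hold more compounds than are shown below. What is called first, only, known or untested is meant among the compounds shown, and "the series" means these compounds.

Measured so far:
compound 1 `CCC1(Cc2ccccc2)OS(=O)(=O)C=C1OCC#N` — > 400000 nM
compound 2 `CC(C)C1(Cc2ccccc2)OS(=O)(=O)C=C1OCc1ccccc1` — >= 80000 nM
compound 3 `CCC1(Cc2ccccc2)OS(=O)(=O)C=C1OCCCCCCc1ccccc1` — >= 20000 nM

The cytotoxicity screen is an ADME assay on HEL cells (Homo sapiens) for cytotoxicity, with a stated time of 3 days; on this read-out higher numbers stand for lower toxicity in this test and lower numbers for higher toxicity in this test. Compound 1 gives only a limit of the assay there, > 400000 nM, and no number. Compound 2 also returns a limit, >= 80000 nM. Compound 3 likewise stands at a limit, >= 20000 nM. Since all three readings are limits, none of the three can be placed relative to another, and compound 1 can only be said to sit at the highest of the three limits, where it is alone (the limit of > 400000 nM in this assay, at which 1 of the 3 values shown sits).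

Compound 4 `CCC1(Cc2ccccc2)OS(=O)(=O)C=C1OCc1ccc(Br)cc1` keeps the core of compound 1 and differs in one place: 4-bromophenyl in place of cyano on a saturated chain carbon bound to an oxygen on an unsaturated carbon. No step between two measured compounds is available to gauge this change, and no shown line bears on the property of the entering group, so the direction can only be guessed from the ether side chains that carry an aromatic ring in compounds 2 and 3. Compound 4 is therefore expected to read lower than the limit of compound 1, by an estimated at least 4.0-fold lower number from compound 1 to compound 4 (0.60 log units; beyond the scatter). Compound 4 is estimated at 100000 nM, within a range from 30000 nM to 400000 nM, with a fair chance that this assay again reports only a limit.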

Compound 4, minimum cytotoxic concentration: 80000 nM
For compound 4 the middle estimate is 1.3-fold (0.10 log units) above the measured one, and the stated range covers the measured number.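

In this assay, putting 4-bromophenyl in place of cyano on a saturated chain carbon bound to an oxygen on an unsaturated carbon gives an at least 5.0-fold lower number from compound 1 to compound 4 (0.69 log units; beyond the scatter), so the read-out at this position does respond to the ether side chain, moving beyond the scatter towards higher toxicity in this test. For the compounds shown here, compound 4 also gives a plain number rather than a limit, which none of the earlier compounds did, and so provides the first firm reference point on the shared core. The size of the step remains a minimum, because the reading for compound 1 is a limit and not a number: the limit of > 400000 nM in this assay, at which 1 of the 4 values shown sits.

The compounds shown do not separate the aromatic ring from the bromine, since the change brings in both at once, and an unsubstituted benzyl ether or a 4-methoxybenzyl ether on the core of compound 1 would show which part carries the step. From the compounds shown here alone, whether an amine or a carboxylic acid at the end of the ether chain would keep the read-out as high as in compound 1 also stays open.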